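This account rests on a few compounds, and the source may have more. Where it says the series, first, only, none or still open, it means among the compounds named here.

In a functional assay on L1210 cells (Mus musculus) for inhibition; a lower number here means a stronger inhibitor, a higher number a weaker inhibitor:
compound 1 `C=C1[C@@H](O)[C@H](n2cnc3c(N)nc(N)nc32)O[C@@H]1CO`: > 200000 nM
compound 2 `C=C1[C@@H](O)[C@H](n2cnc3c(N(C)C)nc(N)nc32)O[C@@H]1CO`: > 500000 nM

The value for compound 1, > 200000 nM, is a limit and not a number. The value for compound 2, > 500000 nM, is also a limit. Compound 1 therefore has no numerical position in the series.

Compound 3 `C=C1[C@@H](O)[C@H](n2cnc3c(N)ncnc32)O[C@@H]1CO` follows from compound 1 by hydrogen in place of amino on an aromatic carbon, between two ring nitrogen atoms. Within the data shown here, the only measured step, a step that the two limits leave unreadable from compound 1 to compound 2, involves dimethylamino in place of amino and has no readable size, so it gives no measure for this change. The expectation in this assay is therefore anchored on compound 1, with its limit of > 200000 nM. A small move towards stronger inhibition is expected, with low confidence: an at least 1.3-fold lower number from compound 1 to compound 3 (0.12 log units; that floor lies within the scatter). Compound 3 is expected at 150000 nM, with an estimated range of 20000 nM to 500000 nM.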

Compound 3, half-maximal inhibitory concentration: 228000 nM
Beside the measured number, compound 3's estimate is 1.5-fold (0.18 log units) below it; the measured number falls inside the stated range.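

In this assay, among these compounds, compound 1 gives > 200000 nM as a limit and not a number, so no step from it to compound 3 can be read: the limit of > 200000 nM in this assay, at which 1 of the 3 values shown sits.

The compounds shown leave open whether hydrogen in place of amino on an aromatic carbon changes inhibition at all, and by how much.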